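The source may hold more compounds than are shown below. What is called first, only, known or untested is meant among the compounds shown, and "the series" means these compounds.

Measured compounds:
- compound 1 `O=C1C2=C(C(=O)c3ccccc31)C1(CS2)NC(=O)N(CCO)C1=O`: 69 nM in a functional assay on MCF7 cells (Homo sapiens) for inhibition; a higher number here means a weaker inhibitor, a lower number a stronger inhibitor
- compound 2 `CN(C)CCN1C(=O)NC2(CSC3=C2C(=O)c2ccccc2C3=O)C1=O`: 32 nM in this assay

Compound 2 holds the lower of the two numbers; its nearest neighbour is compound 1, and the step is a 2.2-fold lower number from compound 1 to compound 2 (0.33 log units; beyond the scatter), a modest gain on exchanging hydroxy for dimethylamino at the end of the chain on the ring nitrogen.

Compound 3 `CCN(CC)CCCN1C(=O)NC2(CSC3=C2C(=O)c2ccccc2C3=O)C1=O` differs from compound 2 by (diethylamino)methyl in place of dimethylamino on a saturated chain carbon, two bonds along the chain from an amide-type nitrogen in a ring. Going by the values given here, the only measured step at this place is a 2.2-fold lower number from compound 1 to compound 2 (0.33 log units; beyond the scatter), and it concerns the switch from a hydroxy to a tertiary amine, not the length of the chain or the size of the alkyls on the amine nitrogen. From the compounds shown here alone, compound 3 keeps the tertiary amine, so the gain seen in that step is assumed to carry over, while the added carbons are untested and give no basis for a further shift. No step beyond the scatter is expected in this assay. Compound 3 is estimated at 30 nM, with a range of 12 nM to 75 nM. This corresponds to an expected step of a 1.1-fold lower number from compound 2 to compound 3 (0.03 log units; within the scatter).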

Compound 3, half-maximal inhibitory concentration: 26 nM
Compound 3: middle estimate off by 1.2-fold (0.06 log units), on the high side, and the stated range covers the measured number.
By their numbers in this assay, from the lowest: compounds 3 and 2 (each within the scatter of the next); then compound 1.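

In this assay, going by these compounds alone, the move from 2-(dimethylamino)ethyl to 3-(diethylamino)propyl on the ring nitrogen stays within the scatter (a 1.2-fold lower number from compound 2 to compound 3 (0.09 log units; within the scatter)), so this position accepts the longer chain and the larger alkyls on the amine together, although the single step cannot separate the two. The hydroxy compound now stands apart from two different tertiary amines, and the step to the second of these is also beyond the scatter (a 2.7-fold lower number from compound 1 to compound 3 (0.42 log units; beyond the scatter)), with neither compound 2 nor compound 3 going against that reading. No supporting measurement bears on the reason for these steps.

Still open, from the compounds shown here alone, is whether the gain follows the tertiary amine itself or would also appear with a primary amine, a morpholine or a carboxylic acid at the chain end. A 2-(diethylamino)ethyl chain and a 3-(dimethylamino)propyl chain would separate chain length from the alkyls on the amine.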